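This account rests on a few compounds, and the source may have more. Where it says the series, first, only, none or still open, it means among the compounds named here.

Compound 2 `O=C(Nc1cc2nc(C3CCCCC3)[nH]c2cc1N1CCCC1)c1ccc(Br)cc1` sits at the limit of an ADME assay on Vero cells (Chlorocebus sabaeus) for cytotoxicity, read by resazurin assay, with a stated time of 3 days (a lower number here means a stronger inhibitor, a higher number a weaker inhibitor), giving > 100 ug/mL, which is a limit of the assay rather than a number. Compound 1 `CN(C)c1cc2[nH]c(C3CCCCC3)nc2cc1NC(=O)c1ccc(Br)cc1` likewise gives > 100 ug/mL, a limit. Compound 3 `CCN(CC)c1cc2[nH]c(C3CCCCC3)nc2cc1NC(=O)c1ccc(F)cc1` gives > 100 ug/mL, also a limit. Among the measured compounds shown here, the one measured step that changes a single group, a step that the two limits leave unreadable from compound 1 to compound 2, is therefore unreadable, since both ends sit at the limit of > 100 ug/mL in this assay, at which 3 of the 3 values shown sit. Compound 4 `CCOCCOC(=O)Nc1cc2nc(C3CCCCC3)[nH]c2cc1N1CCCC1` differs from compound 2 by 2-ethoxyethoxy in place of 4-bromophenyl on a carbonyl carbon. For the measured compounds named here, no measured step touches this carbonyl substituent, and the only step available, from compound 1 to compound 2, gives no size at all. What the numbers show is simply that every compound of this core, with dimethylamino, pyrrolidin-1-yl or diethylamino on the aromatic carbon, reaches the limit. The step from compound 2 to compound 4 is accordingly expected to be a number no higher from compound 2 to compound 4 (the limit leaves the size open), that is none beyond the scatter. Compound 4 is expected to give about 100 ug/mL in this assay, within a range from 50 ug/mL to 200 ug/mL, most likely reported again as a limit.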

Compound 4, half-maximal inhibitory concentration: > 100 ug/mL
Compound 4: a limit, no number; the forecaster's own chance of this, stated with the estimate: 75%; the middle value lies on the limit itself.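

The step between compound 2 and compound 4 cannot be read in this assay, as neither end gives a number: the limit of > 100 ug/mL in this assay, at which 4 of the 4 values shown sit. The compounds shown leave open where any of them would reach half-maximal inhibition, and whether 2-ethoxyethoxy in place of 4-bromophenyl changes it at all.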